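Methyl on the Chain Carbon: Expected Solubility of Compound 4

The source may report more compounds than this note shows. Statements on the series, on what has been measured and on what is new or still open speak of the compounds shown alone.

Compound 1, `COCCn1cc(C(=O)C(=O)Nc2ccc(OCC(=O)O)nc2)c2ccccc21`: in a physicochemical assay for solubility, in phosphate buffer, at pH 7.4 (a higher number here means a more soluble compound, a lower number a less soluble compound), compound 1 gives <= 200000 nM, which is a limit of the assay.
Compound 2, `COc1ccc(NC(=O)C(=O)c2cc(C(C)C)n3ccccc23)cn1`: in this assay compound 2 gives 10000 nM.
Compound 3, `COCC(C)n1cc(C(=O)C(=O)Nc2ccc(OC)nc2)c2ccccc21`: in this assay compound 3 gives 40000 nM.

Among the two numbers given, compound 3 holds the higher one, and its gap to compound 2 lies beyond the usual scatter of repeated measurements. For compound 1 only a limit is known (the limit of <= 200000 nM in this assay, at which 1 of the 3 values shown sits), so it cannot be ranked against the others. For the measured compounds named here, no pair of measured compounds differs in a single place, so no measured step is available to lean on.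

Compound 4, `COCC(C)(C)n1cc(C(=O)C(=O)Nc2ccc(OC)nc2)c2ccccc21`, has not yet been measured in this assay. It differs from compound 3 by methyl in place of hydrogen on a saturated chain carbon bound to an aromatic nitrogen and two saturated chain carbons. Going by the values given here, with no comparable measured step to guide it, the expectation for compound 4 rests only on the change itself and on where compound 3 stands, so the estimated step of a 1.6-fold lower number from compound 3 to compound 4 (0.20 log units; within the scatter) is a modest decrease, close to the edge of the scatter. Compound 4 is therefore expected to give about 25000 nM, with a likely range from 8000 nM to 80000 nM.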

Compound 4, solubility: 10000 nM
Compound 4: the middle estimate sits 2.5-fold (0.40 log units) above what was measured; the measured number falls inside the stated range.
By their numbers in this assay, from the lowest: compounds 2 and 4 (each within the scatter of the next); then compound 3.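

For the compounds shown here, the first measured step at this position comes with methyl in place of hydrogen on a saturated chain carbon bound to an aromatic nitrogen and two saturated chain carbons: in this assay, the change gives a 4.0-fold lower number from compound 3 to compound 4 (0.60 log units; beyond the scatter). Going from 1-(methoxymethyl)ethyl to 1-(methoxymethyl)-1-methylethyl thus moves the read-out beyond the scatter, although the group that enters holds only 1 carbon, with no hydrogen-bond donor or acceptor and no net charge. Nothing among the data shown explains the size of this step.

On these data alone, whether the same change gives a similar step on another core remains open, since this single pair is the only one that differs in one place. Also open, as far as these compounds go, is how an amine or a longer chain at this carbon would read in this assay.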